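Hydroxyphenyl positional isomers and cytotoxicity on kidney cells

The source may hold more compounds than are shown below. What is called first, only, known or untested is meant among the compounds shown, and "the series" means these compounds.

Compound 1 `Oc1cccc(-c2cc(-c3ccccc3O)cc(-c3cccc(O)c3)n2)c1` gives 130 nM in an ADME assay on HEK293 cells (Homo sapiens) for cytotoxicity, read by CCK-8 assay, with a stated time of 4 days; a higher number here means a weaker inhibitor, a lower number a stronger inhibitor. Compound 2 `Oc1cccc(-c2cc(-c3cccc(O)c3)nc(-c3cccc(O)c3)c2)c1` gives 740 nM in this assay; the change 3-hydroxyphenyl in place of 2-hydroxyphenyl on an aromatic carbon made a 5.7-fold higher number from compound 1 to compound 2 (0.76 log units; beyond the scatter). Compound 3 `Oc1ccc(-c2cc(-c3ccccc3O)cc(-c3ccccc3O)n2)cc1` gives 6990 nM in this assay and stands highest of the three; the difference between the cores of compound 3 and compound 1 is not broken down here. Compound 4 `Oc1ccc(-c2cc(-c3cccc(O)c3)cc(-c3ccccc3O)n2)cc1` carries 3-hydroxyphenyl in place of 2-hydroxyphenyl on an aromatic carbon, the same kind of change as between compound 1 and compound 2, though here the place is meta to a 2-hydroxyphenyl group and meta to a 4-hydroxyphenyl group, where before it was meta to two 3-hydroxyphenyl groups. The expected step is a 3.6-fold higher number from compound 3 to compound 4 (0.55 log units; beyond the scatter), resting on a 5.7-fold higher number from compound 1 to compound 2 (0.76 log units; beyond the scatter) with added width for the changed surroundings. Compound 4 is expected to give 25000 nM, between 7000 nM and 90000 nM.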

Compound 4, half-maximal inhibitory concentration: > 50000 nM
Compound 4: no number, only a limit (the forecaster's own chance of this, stated with the estimate: 25%); at least 2.0-fold (0.30 log units) between middle value and limit.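

In this assay, 3-hydroxyphenyl in place of 2-hydroxyphenyl on an aromatic carbon gives an at least 7.1-fold higher number from compound 3 to compound 4 (0.85 log units; beyond the scatter) on the core of compound 3. Compound 4 has only an assay limit, > 50000 nM, not a number. The direction of the step therefore carries over from the core of compound 1 to the core of compound 3, but the data do not show whether its size carries over: the same change on two cores in this assay, a 5.7-fold higher number (0.76 log units; beyond the scatter) from compound 1 to compound 2 and an at least 7.1-fold higher number (0.85 log units; beyond the scatter) from compound 3 to compound 4; the limit leaves it open whether they differ.

The compounds shown leave open whether the same direction holds when an amine or a methoxy group stands in place of the hydroxyl on these phenyl rings. On these data alone, whether it holds on any further core also remains open.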